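Swapping the basic side chain in a diaryl ether series

A few compounds are considered here, and "the series" means these few. Any claim that something is new, unique, unknown or untested is made for them only; others in the source may bear on it.

Measured so far:
- Compound 1 `Cc1cc(/C=C/C#N)cc(C)c1Oc1nc(Nc2ccc(CN3CCNCC3)cc2)nc2sccc12` gives 4030 nM in an ADME assay on MT4 cells (Homo sapiens) for cytotoxicity, read by MTT assay, with a stated time of 5 days; a lower number here means that less compound is tolerated, a higher number that more compound is tolerated.
- Compound 2 `Cc1cc(/C=C/C#N)cc(C)c1Oc1nc(Nc2ccc(N3CCN(S(C)(=O)=O)CC3)cc2)nc2ccsc12` gives 11500 nM in this assay.

Both compounds share the same core and differ only in the group carried on the aryl amine. Of the two numbers, compound 1 has the lower one, so less of it is tolerated by the cells than of compound 2; the gap between them is larger than the scatter of repeated measurements, so the order is real.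

Compound 3 `Cc1cc(/C=C/C#N)cc(C)c1Oc1nc(Nc2ccc(N3CCCC(N)C3)cc2)nc2sccc12` is not yet measured. It is built from compound 1 by a rearrangement of the same atoms: 3-aminopiperidin-1-yl in place of (piperazin-1-yl)methyl on an aromatic carbon. Going by the values given here, no measured pair shows a step of this exact kind, so the expectation rests only on the two values above. Compound 3 is expected to sit close to compound 1, with a step of a 1.2-fold higher number from compound 1 to compound 3 (0.09 log units; within the scatter) that may not exceed the usual scatter. For compound 3 in this assay the estimate is 5000 nM, within a range from 2000 nM to 12000 nM.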

Compound 3, half-maximal cytotoxic concentration: 4610 nM
The estimate for compound 3 lay 1.1-fold (0.04 log units) above the measured number; measured number inside the range.
By their numbers in this assay, from the lowest: compounds 1 and 3 (each within the scatter of the next); then compound 2.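

In this assay, the step of a 1.1-fold higher number from compound 1 to compound 3 (0.06 log units; within the scatter) shows that this position tolerates a considerable rearrangement of the side chain without any change that can be told apart from the scatter. The same atoms are joined quite differently: the ring now carries 1 hetero atom instead of 2, the second nitrogen sits outside it as an amino group, and the ring is attached directly to the aromatic carbon rather than through a methylene link, yet cell tolerance stays level, so these differences in connectivity do not by themselves separate the two compounds in this assay. Nothing available here explains why the two side chains give matching numbers.

As far as these compounds go, both side chains compared on this core contain a six-membered non-aromatic ring and a free amine, so it remains open whether the level seen here depends on those features. A carboxylic acid or an open-chain amine such as a 2-aminoethyl group at the same aromatic carbon would test this, and a morpholine ring would show what happens when the second nitrogen is replaced by an oxygen.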